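Bromine on the shared core and cytotoxicity

The source may hold more compounds than are shown below. What is called first, only, known or untested is meant among the compounds shown, and "the series" means these compounds.

Compound 2 `O=c1n(Cc2cn(Cc3cc4ccccc4nc3Cl)nn2)cnn1-c1ccccc1` is the starting point. In an ADME assay on HEK293 cells (Homo sapiens) for cytotoxicity, read by MTT assay (on this read-out higher numbers stand for weaker inhibition and lower numbers for stronger inhibition), compound 2 gives 655 ug/mL. Among the two measured compounds this is the highest number, but its only neighbour, compound 1 `Cc1ccc2nc(Cl)c(Cn3cc(Cn4cnn(-c5ccccc5)c4=O)nn3)cc2c1`, is close: compound 1 gives 478 ug/mL, and the step of a 1.4-fold higher number from compound 1 to compound 2 (0.14 log units; within the scatter) stays within the scatter, so the two values cannot be told apart.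

Compound 3 `O=c1n(Cc2cn(Cc3cc4cc(Br)ccc4nc3Cl)nn2)cnn1-c1ccccc1` has not yet been measured. It differs from compound 2 in one place: bromo in place of hydrogen on an aromatic carbon.

Among the compounds with values here, only one measured step bears on this change, a 1.4-fold higher number from compound 1 to compound 2 (0.14 log units; within the scatter), which also swaps a hydrogen for a small group on an aromatic carbon of the shared core and produced no difference beyond the scatter. Within the data shown here, a bromine is a different group from a methyl, so this is a loose guide, and there is no second step to check it against.

On that basis the step from compound 2 to compound 3 is expected to be a 1.2-fold lower number from compound 2 to compound 3 (0.08 log units; within the scatter), that is, nothing beyond the scatter. Compound 3 is therefore estimated at 550 ug/mL, with a range from 280 ug/mL to 1000 ug/mL.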

Compound 3, half-maximal inhibitory concentration: 1650 ug/mL
Estimate against measurement, compound 3: 3.0-fold (0.48 log units) below; measured number outside the range, above it.
By their numbers in this assay, from the lowest: compounds 1 and 2 (each within the scatter of the next); then compound 3.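

In this assay, the aromatic carbon that carries the new group now shows that it can respond to a change: bromo in place of hydrogen gives a 2.5-fold higher number from compound 2 to compound 3 (0.40 log units; beyond the scatter), a shift towards weaker inhibition, whereas the earlier swap of methyl for hydrogen stayed within the scatter. Bromo also stands apart from methyl, with a 3.5-fold higher number from compound 1 to compound 3 (0.54 log units; beyond the scatter), so on this carbon it differs from both of the other groups, and both steps are modest in size. Nothing in the data accounts for the effect of this single bromine atom.

The compounds shown leave open whether other groups on this carbon, such as a fluorine, a chlorine, a methoxy group or an amine, would also raise the number, or whether the shift belongs to bromo alone. They also leave open whether bromo on another aromatic carbon of the same ring would give a similar step, as a single bromo compound on one read-out cannot establish a trend.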